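This account rests on a few compounds, and the source may have more. Where it says the series, first, only, none or still open, it means among the compounds named here.

Values measured in an ADME assay on L02 cells (Homo sapiens) for cytotoxicity, read by MTT assay, with a stated time of 48 h; a lower number here means a stronger inhibitor, a higher number a weaker inhibitor:
- Compound 1 `CN1CCN(C[C@H]2CN(c3ccc(-n4cc(-c5ccccn5)cn4)c(F)c3)C(=O)O2)CC1` gives 70 ug/mL
- Compound 2 `O=C1O[C@@H](CN2CCCCC2)CN1c1ccc(-n2cc(-c3ccccn3)cn2)c(F)c1` gives > 400 ug/mL (a limit)
- Compound 3 `O=C(OC[C@H]1CN(c2ccc(-n3cc(-c4ccccn4)cn3)c(F)c2)C(=O)O1)c1ccccc1` gives > 400 ug/mL (a limit)

Compound 3 has no number, only a limit, and so it falls under (the limit of > 400 ug/mL in this assay, at which 2 of the 3 values shown sit). Compound 4 `CN(C)S(=O)(=O)NC[C@H]1CN(c2ccc(-n3cc(-c4ccccn4)cn3)c(F)c2)C(=O)O1` carries (dimethylsulfamoyl)amino in place of benzoyloxy on a saturated chain carbon bound to a saturated ring carbon. Among the compounds with values here, no measured step makes this exact change. The nearest are an at least 5.7-fold higher number from compound 1 to compound 2 (0.75 log units; beyond the scatter) and an at least 5.7-fold higher number from compound 1 to compound 3 (0.75 log units; beyond the scatter), both of which remove 4-methylpiperazin-1-yl, a group compound 4 also lacks. By contrast, a step that the two limits leave unreadable from compound 2 to compound 3 gives no size. In this assay, compound 4 is therefore expected to stay near the limit, with no clear step in either direction. The expected change is a number no higher from compound 3 to compound 4 (the limit leaves the size open). For compound 4 the estimated value is 400 ug/mL, with an expected range of 150 ug/mL to 800 ug/mL.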

Compound 4, half-maximal inhibitory concentration: 158 ug/mL
The estimate for compound 4 lay 2.5-fold (0.40 log units) above the measured number; the range from low to high includes it.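

In this assay, replacing 4-methylpiperazin-1-yl on a saturated chain carbon bound to a saturated ring carbon does not always lead to the limit: (dimethylsulfamoyl)amino gives a 2.3-fold higher number from compound 1 to compound 4 (0.35 log units; beyond the scatter), but also an at least 2.5-fold lower number from compound 3 to compound 4 (0.40 log units; beyond the scatter) and an at least 2.5-fold lower number from compound 2 to compound 4 (0.40 log units; beyond the scatter). The group at this place therefore still moves the number once 4-methylpiperazin-1-yl has gone. The last two steps are open-ended, since compound 2 and compound 3 each carry only a limit: the limit of > 400 ug/mL in this assay, at which 2 of the 4 values shown sit.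

The compounds shown leave open whether the sulfamoyl part or the nitrogen link goes with the lower number. An acetamide or a simple primary amine at this place would separate the two.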